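Notes on the step from compound 3 to compound 4

A few compounds are considered here, and "the series" means these few. Any claim that something is new, unique, unknown or untested is made for them only; others in the source may bear on it.

Values measured in a functional assay on MCF7 cells (Homo sapiens) for inhibition, read by MTT assay (on this read-out higher numbers stand for weaker inhibition and lower numbers for stronger inhibition), follow.
- compound 1 (`COc1cc2ncnc(Nc3ccc(NC(=O)c4ccccc4OC)cc3)c2cc1OC`) gives > 100000 nM
- compound 2 (`CCc1ccc(C(=O)Nc2ccc(Nc3ncnc4cc(OC)c(OC)cc34)cc2)cc1`) gives 65000 nM
- compound 3 (`COc1cc2ncnc(Nc3ccc(NC(=O)c4ccccc4F)cc3)c2cc1OC`) gives 11000 nM

The value for compound 1 is a limit. Compound 3 holds the lowest number of the three. The change to compound 4 (`COc1cc2ncnc(Nc3ccc(NC(=O)c4cccc(I)c4)cc3)c2cc1OC`) puts 3-iodophenyl in place of 2-fluorophenyl on a carbonyl carbon. Two measured steps alter the group on that carbon, both beyond the scatter (a 5.9-fold lower number from compound 2 to compound 3 (0.77 log units; beyond the scatter)) and (an at least 9.0-fold lower number from compound 1 to compound 3 (0.95 log units; beyond the scatter)), the second being only a floor. Going by the values given here, both end at compound 3, and no measured compound carries iodo. Leaving the lowest point of the series, a modest rise is expected (a 1.8-fold higher number from compound 3 to compound 4 (0.26 log units; within the scatter)). The estimate for compound 4 is 20000 nM (expected range 6000 nM to 80000 nM).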

Compound 4, half-maximal inhibitory concentration: 30000 nM
Compound 4: the middle estimate sits 1.5-fold (0.18 log units) below what was measured; low and high end bracket the measured number.
By their numbers in this assay, from the lowest: compound 3; then compound 4; then compound 2. At a limit, above all of these: compound 1.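

In this assay, 3-iodophenyl on the carbonyl carbon gives up ground to 2-fluorophenyl (a 2.7-fold higher number from compound 3 to compound 4 (0.44 log units; beyond the scatter)) yet improves on 4-ethylphenyl (a 2.2-fold lower number from compound 2 to compound 4 (0.34 log units; beyond the scatter)). The comparison with 2-methoxyphenyl yields only a floor (an at least 3.3-fold lower number from compound 1 to compound 4 (0.52 log units; beyond the scatter)): the limit of > 100000 nM in this assay, at which 1 of the 4 values shown sits. Each step is beyond the scatter, so the aryl group on this carbonyl carbon keeps moving the number, and iodo now has a place on that scale.

Still open, on these data alone, is whether the halogen or its place on the ring carries the rise, and how 3-fluorophenyl would read. Also open, as far as these compounds go, is how an amine or a carboxylic acid on this ring would read.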